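Cytotoxicity on Vero cells across three analogues and one more

A few compounds are considered here, and "the series" means these few. Any claim that something is new, unique, unknown or untested is made for them only; others in the source may bear on it.

Compound 1 `NS(=O)(=O)c1ccc(N2N=C(c3ccccc3)CC2c2ccccc2F)cc1` was measured in an ADME assay on Vero 76 cells (Chlorocebus sabaeus) for cytotoxicity, read by MTT assay, with a stated time of 96 h (a higher number here means that more compound is tolerated, a lower number that less compound is tolerated), where compound 1 gives 28000 nM. Compound 2 `Cc1cccc(C2CC(c3ccccc3)=NN2c2ccc(S(N)(=O)=O)cc2)c1` differs from it by 3-methylphenyl in place of 2-fluorophenyl on a saturated ring carbon, and in this assay compound 2 gives 25000 nM; the step of a 1.1-fold lower number from compound 1 to compound 2 (0.05 log units; within the scatter) lies within the scatter. Compound 3 `NS(=O)(=O)c1ccc(N2N=C(c3ccc(OCc4ccccc4)cc3)CC2c2ccccc2F)cc1` differs from compound 1 by benzyloxy in place of hydrogen on an aromatic carbon. In this assay compound 3 reaches only a limit, > 100000 nM. The step of an at least 3.5-fold higher number from compound 1 to compound 3 (0.55 log units; beyond the scatter) is therefore bounded by the limit of > 100000 nM in this assay, at which 1 of the 3 values shown sits.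

Compound 4 `Cc1cccc(C2CC(c3ccc(OCc4ccccc4)cc3)=NN2c2ccc(S(N)(=O)=O)cc2)c1` is not yet measured. It differs from compound 3 by 3-methylphenyl in place of 2-fluorophenyl on a saturated ring carbon, the same kind of change that separates compound 1 from compound 2, though here the ring atom next to the place bears a 4-sulfamoylphenyl group and the atom two ring bonds away bears a large group. The two cores differ by benzyloxy in place of hydrogen on an aromatic carbon.

The step from compound 3 to compound 4 is expected to be a number no higher from compound 3 to compound 4 (the limit leaves the size open), because a 1.1-fold lower number from compound 1 to compound 2 (0.05 log units; within the scatter) stayed within the scatter. Compound 4 is expected to give 100000 nM, estimated between 50000 nM and 200000 nM, most likely again as a limit.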

Compound 4, half-maximal cytotoxic concentration: 100000 nM
Estimate against measurement, compound 4: no gap at the digits printed; low and high end bracket the measured number.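

Benzyloxy in place of hydrogen on an aromatic carbon gives a 4.0-fold higher number from compound 2 to compound 4 (0.60 log units; beyond the scatter) in this assay, so the number rises beyond the scatter on the core carrying 3-methylphenyl, as it does on the core carrying 2-fluorophenyl: the same change on two cores in this assay, an at least 3.5-fold higher number (0.55 log units; beyond the scatter) from compound 1 to compound 3 and a 4.0-fold higher number (0.60 log units; beyond the scatter) from compound 2 to compound 4; the limit leaves it open whether they differ

The exchange of 2-fluorophenyl for 3-methylphenyl gives a number no higher from compound 3 to compound 4 (the limit leaves the size open) on the core bearing benzyloxy, so its size cannot be read and it is not shown to carry over unchanged from the core of compound 1: the same change on two cores in this assay, a 1.1-fold lower number (0.05 log units; within the scatter) from compound 1 to compound 2 and a number no higher (the limit leaves the size open) from compound 3 to compound 4; the limit leaves it open whether they differ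

Compound 3 gives > 100000 nM, which is a limit of the assay, so the two benzyloxy steps share a direction but are not shown to match in size: the limit of > 100000 nM in this assay, at which 1 of the 4 values shown sits.

The compounds shown leave open whether a methoxy or a hydroxy group in the place of benzyloxy would move the number in the same way. They also leave open whether an amine or a carboxylic acid on the phenyl ring at the saturated ring carbon would keep the number where these two aryl groups leave it.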